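Lengthening a Chloroalkyl Chain: What to Expect of Compound 4

The source may report more compounds than this note shows. Statements on the series, on what has been measured and on what is new or still open speak of the compounds shown alone.

The measured compounds:
Compound 1 `O=C(CSc1nnc(NC(=O)CCl)s1)Nc1ccc(Cl)cn1`, in a functional assay on A875 cells (Homo sapiens) for antiproliferative activity, read by MTT assay, with a stated time of 48 h (a higher number here means a weaker inhibitor, a lower number a stronger inhibitor), compound 1 gives 8600 nM.
Compound 2 `O=C(CSc1nnc(NC(=O)CCCCl)s1)Nc1ccc(Cl)cn1`. In this assay compound 2 reaches only a limit, > 80000 nM.
Compound 3 `O=C(CCl)Nc1ccc(SCC(=O)Nc2ccc(Cl)cn2)cc1`, in this assay compound 3 gives 98 nM, the lowest number of the two that are numbers.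

Compound 1 and compound 2 share a core and differ by 2-chloroethyl in place of chloro on a saturated chain carbon bound to a carbonyl carbon; the step is an at least 9.3-fold higher number from compound 1 to compound 2 (0.96 log units; beyond the scatter), where compound 2 sits at the limit (the limit of > 80000 nM in this assay, at which 1 of the 3 values shown sits). Compound 3 has a different core; the difference between the two cores is not broken down here. Compound 4 `O=C(CCCCl)Nc1ccc(SCC(=O)Nc2ccc(Cl)cn2)cc1` carries the same change on the core of compound 3, namely (2-chloroethyl in place of chloro on a saturated chain carbon bound to a carbonyl carbon). Among the measured compounds shown here, since the only precedent is an at least 9.3-fold higher number from compound 1 to compound 2 (0.96 log units; beyond the scatter), a weakening of similar size is expected, a 26-fold higher number from compound 3 to compound 4 (1.41 log units; beyond the scatter). Compound 4 is thus estimated at 2500 nM, between 600 nM and 20000 nM.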

Compound 4, half-maximal inhibitory concentration: > 80000 nM
Compound 4 gave a limit, no number (the forecaster's own chance of this, stated with the estimate: 10%); at least 32-fold (1.50 log units) between middle value and limit.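

In this assay, putting 2-chloroethyl in place of chloro on a saturated chain carbon bound to a carbonyl carbon gives an at least 810-fold higher number from compound 3 to compound 4 (2.91 log units; beyond the scatter), so the change weakens the compounds on the core of compound 3 as it does on the core of compound 1. The direction therefore carries over from one core to the other, but the size of the step does not transfer in any readable way: the same change on two cores in this assay, an at least 9.3-fold higher number (0.96 log units; beyond the scatter) from compound 1 to compound 2 and an at least 810-fold higher number (2.91 log units; beyond the scatter) from compound 3 to compound 4; the limit leaves it open whether they differ Neither longer-chain compound gives a number, so how far each lies from its chloromethyl partner remains unknown: the limit of > 80000 nM in this assay, at which 2 of the 4 values shown sit.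

The compounds shown leave open how a chain shorter than 3-chloropropyl but longer than chloromethyl would read on either core. They also leave open what an amine or a bromine in place of the chlorine of the chloromethyl group would give.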